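A few compounds are considered here, and "the series" means these few. Any claim that something is new, unique, unknown or untested is made for them only; others in the source may bear on it.

Compound 1, `CN(N)c1nnc(-c2ccc(-c3ccccc3)cc2)s1`, gives 27 mg/kg in a functional assay on the whole organism (Hindlimb) for inhibition, with Mus musculus as the target, with a stated time of 1 h; on this read-out higher numbers stand for an effect only at larger amounts of compound and lower numbers for an effect already at smaller amounts.
Compound 2, `C/N=C(\N)Nc1nnc(-c2ccccc2C(F)(F)F)s1`, gives 44 mg/kg in this assay.
Compound 3, `CN(C)CCC/N=C(\N)Nc1nnc(-c2ccccc2C(F)(F)F)s1`, gives in this assay only the limit > 100 mg/kg.

Two of the three compounds carry numbers in this assay. Compound 2 and compound 1 lie within the usual scatter of each other, so no order between them can be read from these figures. For compound 3 the result is a limit of the assay, not a number, as the limit of > 100 mg/kg in this assay, at which 1 of the 3 values shown sits, records.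

Compound 4, `FC(F)(F)c1ccccc1-c1nnc(NC2=NCCN2)s1`, has not yet been measured. Compared with compound 2 it shows (a group of 5 heavy atoms (3 carbon, 2 nitrogen; one five-membered non-aromatic ring with 2 hetero atoms) in place of a group of 4 heavy atoms (2 carbon, 2 nitrogen; no ring), on a nitrogen on an aromatic ring). Going by the values given here, the only measured step touching the same region of the molecule is an at least 2.2-fold higher number from compound 2 to compound 3 (0.35 log units; beyond the scatter), where a larger chain was attached on a saturated carbon bound to the double-bonded nitrogen. The change to compound 4 is smaller and closes the group into a ring rather than extending it, so a step of that size is not expected here. For compound 4 the estimate in this assay is 45 mg/kg, between 18 mg/kg and 110 mg/kg, which is expected to mean a 1.0-fold higher number from compound 2 to compound 4 (0.01 log units; within the scatter), within the scatter.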

Compound 4, dose for half-maximal effect: > 100 mg/kg
Compound 4 gave a limit, no number; the forecaster's own chance of this, stated with the estimate: 20%; middle value at least 2.2-fold (0.34 log units) from the limit.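

Closing the open group of compound 2 into a five-membered non-aromatic ring with 2 hetero atoms, on a nitrogen on an aromatic ring, gives an at least 2.2-fold higher number from compound 2 to compound 4 (0.35 log units; beyond the scatter) in this assay. This place on the molecule therefore does not need a long added chain to lose effect: earlier only the 2-(dimethylamino)ethyl group had shown such a shift, with an at least 2.2-fold higher number from compound 2 to compound 3 (0.35 log units; beyond the scatter), and the ring is a much smaller change. The result for compound 4 is a limit of the assay and not a number, so the full size of its step stays unknown, and it joins compound 3 at the same limit: the limit of > 100 mg/kg in this assay, at which 2 of the 4 values shown sit.

The compounds shown cannot tell whether the ring itself or the loss of the open group matters more. A plain amine at this place, or a six-membered ring, would help separate these two readings.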